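Bis(alkylamino) variant of the phenyl-substituted core

The compounds below may be only part of what the source reports. "The series", "measured", "known", "first", "only" and "open" are said of these compounds alone.

Measured so far:
compound 1 `CCCNc1ncnc2c1cnn2-c1ccccc1` — > 100000 nM
compound 2 `CCc1nc(NC(C)C)c2cnn(-c3ccccc3)c2n1` — 38000 nM

In a functional assay on G-361 cells (Homo sapiens) for cytotoxicity, read by sulforhodamine B assay (on this read-out lower numbers stand for stronger inhibition of growth and higher numbers for weaker inhibition of growth), compound 1 gives only a limit, > 100000 nM, so it stands at the weak end of what has been recorded; see (the limit of > 100000 nM in this assay, at which 1 of the 2 values shown sits). In this assay compound 2 gives 38000 nM, a number rather than a limit. Compound 2 is not a single-point neighbour of compound 1, so the two values show only that one sits at the limit and the other inside the measured range.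

Compound 3 `CCCNc1nc(NCCC)c2cnn(-c3ccccc3)c2n1` is not yet measured. It differs from compound 1 by propylamino in place of hydrogen on an aromatic carbon, between two ring nitrogen atoms.

Going by the values given here, no measured step covers this change. The starting point being a limit, the step can only be a bound. Compound 3 is expected to move toward stronger inhibition of growth, by an at least 3.3-fold lower number from compound 1 to compound 3 (0.52 log units; beyond the scatter), beyond the scatter but modestly. For compound 3 the estimate in this assay is 30000 nM, with a range from 8000 nM to 100000 nM.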

Compound 3, concentration for 50% growth inhibition: > 100000 nM
Compound 3: only a limit was reported; the forecaster's own chance of this, stated with the estimate: 30%; middle value at least 3.3-fold (0.52 log units) from the limit.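

In this assay compound 3 gives > 100000 nM, a limit and not a number. Compound 1 also stands at a limit, so no step between compound 1 and compound 3 can be read: the limit of > 100000 nM in this assay, at which 2 of the 3 values shown sit.

The compounds shown leave open whether propylamino in place of hydrogen on an aromatic carbon changes growth inhibition at all.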